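Aryl swap on the ring nitrogen: compound 3 to compound 4

The source may hold more compounds than are shown below. What is called first, only, known or untested is meant among the compounds shown, and "the series" means these compounds.

Measured compounds:
compound 1, `COc1ccccc1-n1nncc1CN1C(=O)C2(C(C#N)=C(N)Oc3c2c2nc4ccccc4nc2c2ccccc32)c2ccccc21` — > 50000 nM
compound 2, `N#CC1=C(N)Oc2c(c3nc4ccccc4nc3c3ccccc23)C12C(=O)N(Cc1cnnn1-c1cccc(S(N)(=O)=O)c1)c1ccccc12` — 38600 nM
compound 3, `N#CC1=C(N)Oc2c(N)cc3nc4ccccc4nc3c2C12C(=O)N(Cc1cnnn1-c1ccc(Cl)cc1)c1ccccc12` — > 50000 nM

In an ADME assay on HUVEC cells (Homo sapiens) for antiproliferative activity, read by MTT assay, with a stated time of 48 h (on this read-out lower numbers stand for stronger inhibition and higher numbers for weaker inhibition), compound 1 gives > 50000 nM, which is a limit of the assay and not a number. Compound 2 gives 38600 nM in this assay. Compound 3 gives > 50000 nM in this assay, again a limit rather than a number. Compound 3 thus stands at the limit of > 50000 nM in this assay, at which 2 of the 3 values shown sit, so its position within the series cannot be ordered against compound 1, and only the measured number for compound 2 lies inside the range of the assay.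

One measured step changes the aryl group on the aromatic nitrogen: an at least 1.2-fold lower number from compound 1 to compound 2 (0.11 log units; that floor lies within the scatter), 3-sulfamoylphenyl in place of 2-methoxyphenyl. Among the compounds with values here, its floor lies within the scatter, so that change gave no step that can be called real.

Compound 4, `N#CC1=C(N)Oc2c(N)cc3nc4ccccc4nc3c2C12C(=O)N(Cc1cnnn1-c1ccc([N+](=O)[O-])cc1[N+](=O)[O-])c1ccccc12`, differs from compound 3 as follows: 2,4-dinitrophenyl in place of 4-chlorophenyl on an aromatic nitrogen. Within the data shown here, the only step at the same place, an at least 1.2-fold lower number from compound 1 to compound 2 (0.11 log units; that floor lies within the scatter), bears on it, and it was within the scatter. No step beyond the scatter is therefore expected in this assay from compound 3 to compound 4, and a further limit is the most likely outcome. Compound 4 is estimated at 50000 nM, with a range from 20000 nM to 100000 nM. The expected step is a number no higher from compound 3 to compound 4 (the limit leaves the size open).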

Compound 4, half-maximal inhibitory concentration: > 50000 nM
Compound 4: only a limit was reported (the forecaster's own chance of this, stated with the estimate: 70%); the middle value lies on the limit itself.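

In this assay compound 4 gives > 50000 nM as a limit and not a number. Within the data shown here, compound 3 also stands at a limit, so no step from compound 3 to compound 4 can be read: the limit of > 50000 nM in this assay, at which 3 of the 4 values shown sit. Going by these compounds, whether 2,4-dinitrophenyl in place of 4-chlorophenyl changes this read-out at all, and by how much, remains open.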